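The source may report more compounds than this note shows. Statements on the series, on what has been measured and on what is new or still open speak of the compounds shown alone.

Compound 1 `S=C(SCc1nc2cc(Cl)c(Cl)cc2[nH]1)N1CCOCC1` and compound 2 `S=C(SCc1nc2cc(Cl)c(Cl)cc2[nH]1)N1CCCCC1` share one core and differ only in the group on the thiocarbonyl carbon. In a functional assay on MCF7 cells (Homo sapiens) for cytotoxicity, read by MTT assay, with a stated time of 24 h (a higher number here means a weaker inhibitor, a lower number a stronger inhibitor), compound 1 gives 5700 nM, while compound 2 gives 42800 nM, the higher of the two numbers and thus the weaker inhibitor; that single change was a 7.5-fold higher number from compound 1 to compound 2 (0.88 log units; beyond the scatter). Compound 3 `CCN(CC)C(=S)SCc1nc2cc(Cl)c(Cl)cc2[nH]1` takes the next step: diethylamino in place of piperidin-1-yl on a thiocarbonyl carbon. Among the compounds with values here, the only measured step concerns a different exchange, a ring with an oxygen for a ring without one, so no measured pair speaks directly to opening the ring into a chain, and the expectation leans on compound 2 alone. The step is expected to be a 1.2-fold lower number from compound 2 to compound 3 (0.09 log units; within the scatter), lying within the usual scatter, in either direction. Compound 3 is therefore estimated at 35000 nM, with a range from 10000 nM to 100000 nM.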

Compound 3, half-maximal inhibitory concentration: 12600 nM
For compound 3 the middle estimate is 2.8-fold (0.44 log units) above the measured one, within the range that was stated.
By their numbers in this assay, from the lowest: compound 1; then compound 3; then compound 2.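

In this assay, the group on the thiocarbonyl carbon matters even when no ring oxygen is involved: replacing piperidin-1-yl with diethylamino gives a 3.4-fold lower number from compound 2 to compound 3 (0.53 log units; beyond the scatter) and shows that a ring is not required here for the lower number. Morpholin-4-yl still holds the lowest number of the three, since replacing it with diethylamino gives a 2.2-fold higher number from compound 1 to compound 3 (0.34 log units; beyond the scatter). The number of compound 3 thus lies between those of compound 1 and compound 2. No available evidence explains why these three groups rank in this order.

Still open, as far as these compounds go, is how a shorter dimethylamino group, a longer dibutylamino chain or a piperazin-1-yl ring would fare on this carbon. The compounds shown also leave open whether this order would hold with another group in place of the two chlorines on the shared core.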